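Amide substituent variation on a shared nucleoside core

The source may hold more compounds than are shown below. What is called first, only, known or untested is meant among the compounds shown, and "the series" means these compounds.

Measured compounds:
compound 1, `CCCCCCCNC(=O)[C@H]1OC(n2cnc3c(N)ncnc32)[C@H](O)[C@@H]1O`, in an assay on cell membranes for binding affinity to 2-oxoglutarate receptor 1 (Rattus norvegicus), read by radioligand binding (on this read-out lower numbers stand for stronger inhibition and higher numbers for weaker inhibition), compound 1 gives 20 nM.
compound 2, `NCCCCCCCCNC(=O)[C@H]1OC(n2cnc3c(N)ncnc32)[C@H](O)[C@@H]1O`, in this assay compound 2 gives 29 nM.

Compound 2 holds the higher of the two numbers, but the step between them is a 1.5-fold higher number from compound 1 to compound 2 (0.16 log units; within the scatter), so the two stand together within the scatter. The change to compound 3, `CC1CCCCC1NC(=O)[C@H]1OC(n2cnc3c(N)ncnc32)[C@H](O)[C@@H]1O`, is 2-methylcyclohexyl in place of 8-aminooctyl on an amide-type nitrogen. Going by the values given here, no measured step covers such an exchange of a chain for a ring. Among the compounds with values here, the only step available, a 1.5-fold higher number from compound 1 to compound 2 (0.16 log units; within the scatter), shows that altering the far end of the chain leaves the number within the scatter, and says nothing about replacing the whole group on the amide-type nitrogen. The expectation for compound 3 is therefore uncertain and is set as a step of a 2.1-fold higher number from compound 2 to compound 3 (0.32 log units; beyond the scatter) towards a higher number. Compound 3 is estimated at 60 nM, with a range from 15 nM to 250 nM.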

Compound 3, inhibition constant: 69.5 nM
For compound 3 the middle estimate is 1.2-fold (0.06 log units) below the measured one, and the stated range covers the measured number.
By their numbers in this assay, from the lowest: compounds 1 and 2 (each within the scatter of the next); then compound 3.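

In this assay, going by these compounds alone, exchanging a chain for a ring on the amide-type nitrogen gives the only steps beyond the scatter in this set: a 2.4-fold higher number from compound 2 to compound 3 (0.38 log units; beyond the scatter) with 8-aminooctyl leaving, and a 3.5-fold higher number from compound 1 to compound 3 (0.54 log units; beyond the scatter) with heptyl leaving. Both steps run towards a higher number, so this position does respond to replacing the whole group, whereas the change at the far end of the chain stayed within the scatter. No supporting evidence bears on this result.

On these data alone, it remains open whether the step belongs to the ring itself or to its methyl group, a question that plain cyclohexyl would address alongside 2-methylcyclohexyl. As far as these compounds go, how a carboxylic acid at the chain end, a shorter chain or a longer chain would read on the amide-type nitrogen also remains open.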